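Phenyl in Place of Dichlorophenyl on a Shared Core

The source may report more compounds than this note shows. Statements on the series, on what has been measured and on what is new or still open speak of the compounds shown alone.

Measured compounds:
compound 1, `CC(=O)N1N=C(c2ccc(-n3c(C)ccc3C)cc2)OC1c1cccc([N+](=O)[O-])c1`: 197000 nM
compound 2, `CC(=O)N1N=C(c2ccc(-n3c(C)ccc3C)cc2)OC1c1ccc(O)cc1`: 190000 nM
compound 3, `CC(=O)N1N=C(c2ccc(-n3c(C)ccc3C)cc2)OC1c1c(Cl)cccc1Cl`: 224000 nM

Three compounds with one shared core, differing only in the aryl group on a saturated ring carbon, were tested in an ADME assay on A549 cells (Homo sapiens) for cytotoxicity, read by MTT assay, with a stated time of 72 h; on this read-out lower numbers stand for stronger inhibition and higher numbers for weaker inhibition. In this assay compound 1 gives 197000 nM, compound 2 gives 190000 nM and compound 3 gives 224000 nM. The three numbers sit close together: a 1.0-fold lower number from compound 1 to compound 2 (0.02 log units; within the scatter), a 1.1-fold higher number from compound 1 to compound 3 (0.06 log units; within the scatter) and a 1.2-fold higher number from compound 2 to compound 3 (0.07 log units; within the scatter). Compound 3 has the highest number of the three, yet its distance to compound 1 and to compound 2 both fall within the scatter, so no order among them can be read.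

Compound 4, `CC(=O)N1N=C(c2ccc(-n3c(C)ccc3C)cc2)OC1c1ccccc1`, has not yet been measured in this assay. It differs from compound 3 by phenyl in place of 2,6-dichlorophenyl on a saturated ring carbon. Among the compounds with values here, the steps that bear on this change are the three aryl exchanges already seen on that same saturated ring carbon, every one within the scatter. Because a 1.1-fold higher number from compound 1 to compound 3 (0.06 log units; within the scatter) and a 1.2-fold higher number from compound 2 to compound 3 (0.07 log units; within the scatter) are both within the scatter, no step beyond the scatter is expected here either. Compound 4 is expected to give 205000 nM, with a range from 120000 nM to 350000 nM. The expected step is therefore a 1.1-fold lower number from compound 3 to compound 4 (0.04 log units; within the scatter).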

Compound 4, half-maximal inhibitory concentration: 198000 nM
Compound 4: middle estimate off by 1.0-fold (0.02 log units), on the high side; measured number inside the range.
By their numbers in this assay, from the lowest: compounds 2, 1, 4 and 3 (each within the scatter of the next).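

Compound 4, with its bare phenyl, gives the series an unsubstituted reference in this assay, so that each substituent on the aryl ring can now be read alone: a 1.1-fold lower number from compound 3 to compound 4 (0.05 log units; within the scatter) for the two chlorines, a 1.0-fold higher number from compound 2 to compound 4 (0.02 log units; within the scatter) for the hydroxy and a 1.0-fold higher number from compound 1 to compound 4 (0.00 log units; within the scatter) for the nitro. None of these three groups separates from plain hydrogen, so among the compounds shown, the aryl group on this saturated ring carbon can carry any of them without a step beyond the scatter. Nothing available explains this sameness.

Going by these compounds, it remains open whether an amine or a carboxylic acid on that aryl ring would give a step beyond the scatter. On these data alone, it also remains open whether a longer chain in place of the acetyl group would do so.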